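The source may report more compounds than this note shows. Statements on the series, on what has been measured and on what is new or still open speak of the compounds shown alone.

Compound 3, `O=C(c1ccccc1Cl)N1N=C(c2cc3ccccc3oc2=O)CC1c1ccccc1`, was tested in a functional assay on MGC-803 cells (Homo sapiens) for cytotoxicity, read by MTT assay, with a stated time of 48 h (a higher number here means a weaker inhibitor, a lower number a stronger inhibitor), where it gives 6640 nM. Among the three numbers measured so far, this is the second highest. The nearest number belongs to compound 2, `COc1ccccc1C1CC(C)=NN1C(=O)C[N+]1(C)CCCC1`, which in this assay gives 12200 nM; the two values sit within the usual scatter of each other, so no order between them can be read. The furthest number belongs to compound 1, `CC(=O)Oc1ccccc1C1CC(C)=NN1C(=O)CCl`, which in this assay gives 3010 nM; this value lies beyond the scatter from that of compound 3, so compound 1 is the stronger inhibitor of the two.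

The step to compound 4, `O=C(CN1CCCC1)N1N=C(c2cc3ccccc3oc2=O)CC1c1ccccc1`, changes the group on the carbonyl carbon: (pyrrolidin-1-yl)methyl in place of 2-chlorophenyl on a carbonyl carbon. For the measured compounds named here, no two measured compounds differ in one place, so there is no measured step of this kind to lean on. The expectation is therefore that the value of compound 4 stays close to that of compound 3, with a step from compound 3 to compound 4 of a 1.1-fold higher number from compound 3 to compound 4 (0.05 log units; within the scatter), which is not expected to exceed the scatter in either direction. Compound 4 is estimated at 7500 nM in this assay, with a range from 2500 nM to 22000 nM.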

Compound 4, half-maximal inhibitory concentration: "not active" (no number reported)
Compound 4 has no reported number here, and the estimate cannot be compared.
By their numbers in this assay, from the lowest: compound 1; then compounds 3 and 2 (each within the scatter of the next).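

For the compounds shown here, compound 4 is reported as "not active" in this assay with no number, so no step from compound 3 to compound 4 can be read. The compounds shown leave open how far (pyrrolidin-1-yl)methyl in place of 2-chlorophenyl on a carbonyl carbon shifts the value. No available evidence bears on this result.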